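Adding a Second Fluorine to the Benzylamide Ring

This account rests on a few compounds, and the source may have more. Where it says the series, first, only, none or still open, it means among the compounds named here.

Measured so far:
compound 1, `CC(=O)NC(C(=O)NCc1ccccc1F)c1ccco1`, 40 mg/kg
compound 2, `CC(=O)NC(C(=O)NCc1cccc(F)c1)c1ccco1`, 13.3 mg/kg

Both compounds share the same core and differ only in where a single fluoro group sits on the phenyl ring. For the measured compounds named here, in a functional assay on the whole organism with Mus musculus as the target, in the maximal electroshock model (a higher number here means that more compound is needed for the effect, a lower number that less compound is needed), compound 2 gives 13.3 mg/kg, the lowest of the two numbers; the only other value, from compound 1, stands a 3.0-fold lower number from compound 1 to compound 2 (0.48 log units; beyond the scatter) apart, so compound 2 needs the smaller dose of the two.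

Compound 3, `CC(=O)NC(C(=O)NCc1cc(F)ccc1F)c1ccco1`, keeps everything in compound 2 and adds one more fluoro group: fluoro in place of hydrogen on an aromatic carbon. The new group sits ortho to a large group and para to the fluoro group already present.

Going by the values given here, only one measured step bears on this, the move of the fluoro group between compound 1 and compound 2, which was a 3.0-fold lower number from compound 1 to compound 2 (0.48 log units; beyond the scatter). Among the compounds with values here, no measured pair shows what a second fluoro group on this ring does, so the step to compound 3 is uncertain. Since the fluoro group placed as in compound 1 gave the higher number, 40 mg/kg, and the placement kept in compound 2 gave the lower, a modest rise in this assay is expected, a 1.5-fold higher number from compound 2 to compound 3 (0.18 log units; within the scatter). Compound 3 is therefore estimated at 20 mg/kg, within 8 mg/kg to 50 mg/kg.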

Compound 3, dose for half-maximal effect: 23.8 mg/kg
Beside the measured number, compound 3's estimate is 1.2-fold (0.08 log units) below it; measured number inside the range.
By their numbers in this assay, from the lowest: compounds 2, 3 and 1 (each within the scatter of the next, the first and the last beyond it).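

In this assay, adding a second fluoro group ortho to a large group on the ring gives a 1.8-fold higher number from compound 2 to compound 3 (0.25 log units; within the scatter). The comparison with the other single-fluoro compound gives a 1.7-fold lower number from compound 1 to compound 3 (0.23 log units; within the scatter). Neither step lies beyond the usual scatter, so this ring accepts a second fluoro group with no clear change in the dose needed, something the earlier pair could not show because it only moved one fluoro group from one place to another. Nothing available here explains this outcome.

The compounds shown leave open whether the ortho position would respond in the same way to a group with more atoms, such as trifluoromethyl or methoxy, or to an amine, since fluoro is the only group tried there. They also leave open whether the gap between compound 1 and compound 2 would persist with a chloro group in place of fluoro, and whether two fluoro groups placed differently on the ring would give a step beyond the scatter.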